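Replacing the Para Amide: Methylsulfonyl Analog of Compound 3

This account rests on a few compounds, and the source may have more. Where it says the series, first, only, none or still open, it means among the compounds named here.

Compounds measured in an ADME assay on microsomes from liver (Homo sapiens) for metabolic stability; a lower number here means that the compound disappears faster, a higher number that the compound lasts longer:
- compound 1, `COc1cc(OCc2csc(-c3ccc(C(C)(C)O)cc3)n2)c2cc(-c3cn4nc(OC)sc4n3)oc2c1`, 1.83 h
- compound 2, `CNC(=O)c1ccc(-c2nc(COc3cc(OC)cc4oc(-c5cn6nc(OC)sc6n5)cc34)cs2)cc1`, 0.983 h
- compound 3, `COc1cc(OCc2csc(-c3ccc(C(N)=O)cc3)n2)c2cc(-c3cn4nc(OC)sc4n3)oc2c1`, 1.38 h

Compound 3 stands second highest of the three numbers in this assay. Its nearest neighbour is compound 1, a 1.3-fold lower number from compound 1 to compound 3 (0.12 log units; within the scatter), and its furthest is compound 2, a 1.4-fold higher number from compound 2 to compound 3 (0.15 log units; within the scatter); both steps lie within the scatter, so the three compounds cannot be ordered with confidence.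

Compound 4, `COc1cc(OCc2csc(-c3ccc(S(C)(=O)=O)cc3)n2)c2cc(-c3cn4nc(OC)sc4n3)oc2c1`, has not yet been measured in this assay. It differs from compound 3 in one place: methylsulfonyl in place of carbamoyl on an aromatic carbon.

Among the compounds with values here, none of the measured steps covers this exact change. The closest are those at the same aromatic carbon: a 1.9-fold lower number from compound 1 to compound 2 (0.27 log units; within the scatter) and a 1.3-fold lower number from compound 1 to compound 3 (0.12 log units; within the scatter), both within the scatter, and the nitrogen substitution a 1.4-fold higher number from compound 2 to compound 3 (0.15 log units; within the scatter), also within the scatter. Within the data shown here, every variation tried at this position so far has left the half-life essentially where it was. On that basis no step beyond the scatter is expected for compound 4, whose number is estimated at 1.3 h, between 0.65 h and 2.6 h, which corresponds to an expected step of a 1.1-fold lower number from compound 3 to compound 4 (0.03 log units; within the scatter).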

Compound 4, half-life: 1.22 h
Beside the measured number, compound 4's estimate is 1.1-fold (0.03 log units) above it, and the stated range covers the measured number.
By their numbers in this assay, from the lowest: compounds 2, 4, 3 and 1 (each within the scatter of the next).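

In this assay, the place on the aromatic carbon para to a large group now holds methylsulfonyl, which has 0 hydrogen-bond donors and 2 hydrogen-bond acceptors where carbamoyl has 1 of each, and this exchange of the 4-carbamoylphenyl for the 4-(methylsulfonyl)phenyl gives only a small step (a 1.1-fold lower number from compound 3 to compound 4 (0.05 log units; within the scatter)). The other two comparisons at this place tell the same story, with methylsulfonyl set against methylcarbamoyl (a 1.2-fold higher number from compound 2 to compound 4 (0.09 log units; within the scatter)) and against 1-hydroxy-1-methylethyl (a 1.5-fold lower number from compound 1 to compound 4 (0.18 log units; within the scatter)), so the half-life in all four compounds stays within the scatter, even with a sulfur-containing group and no amide at this place. Nothing shown here gives a reason for this result.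

As far as these compounds go, whether an amine, a carboxylic acid or a longer chain at this same place would also stay within the scatter remains open. All four compounds share the same core, so they also cannot tell whether a change anywhere outside this one place would move the number in this assay.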